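Removing a Fluoro Group: What Cytotoxicity to Expect

A few compounds are considered here, and "the series" means these few. Any claim that something is new, unique, unknown or untested is made for them only; others in the source may bear on it.

Compound 2 (`Fc1ccc(-n2cc(COc3ccccc3-c3nc4ccccc4s3)nn2)cc1`) has been tested in a functional assay on MCF7 cells (Homo sapiens) for cytotoxicity, read by MTT assay, with a stated time of 24 h (a higher number here means a weaker inhibitor, a lower number a stronger inhibitor), where compound 2 gives 26200 nM. Within the data shown here, its only measured companion is compound 1 (`Brc1ccc(-c2cc(COc3ccccc3-c3nc4ccccc4s3)on2)cc1`), which in this assay gives 20000 nM; the two numbers lie within the usual scatter of each other, so nothing separates them. Compound 3 (`c1ccc(-n2cc(COc3ccccc3-c3nc4ccccc4s3)nn2)cc1`) has not yet been measured. It differs from compound 2 in one place: hydrogen in place of fluoro on an aromatic carbon. Among the measured compounds shown here, no step between two measured compounds is available here, so there is no measured step on which to lean. With only the fluoro group gone, the expectation is for no shift beyond the scatter in this assay, and the estimated step of a 1.0-fold lower number from compound 2 to compound 3 (0.00 log units; within the scatter) reflects that. Compound 3 is therefore expected to give about 26000 nM, with a likely range from 11000 nM to 60000 nM.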

Compound 3, half-maximal inhibitory concentration: 26200 nM
Compound 3: the middle estimate sits 1.0-fold (0.00 log units) below what was measured, and the stated range covers the measured number.
By their numbers in this assay, from the lowest: compounds 1, 2 and 3 (each within the scatter of the next).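

In this assay, among these compounds, the swap of 4-fluorophenyl to phenyl gives no change at the digits printed from compound 2 to compound 3 (within the scatter) and this is the first measured step between two compounds that differ in one place. It shows that, on this aromatic carbon para to a large group, the fluoro group is not needed for the cytotoxicity seen here, since hydrogen does just as well in this read-out. Nothing measured here accounts for this flat result.

Going by these compounds, whether a larger or differently built group at this place, such as an amine, a carboxylic acid or a longer chain, would move the number remains open. Also open, on these data alone, is whether changes elsewhere on the shared core would shift cytotoxicity, as this single step speaks only to the swap of fluoro for hydrogen.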